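Dichlorothienopyrimidine ureas: side-chain amine variation

The compounds below may be only part of what the source reports. "The series", "measured", "known", "first", "only" and "open" are said of these compounds alone.

Measured so far in a functional assay on NCI-H460 cells (Homo sapiens) for cytotoxicity, read by MTT assay, with a stated time of 72 h; a lower number here means a stronger inhibitor, a higher number a weaker inhibitor:
compound 1 `CN(C)CCCNc1nc(-c2ccc(NC(=O)Nc3ccc(Cl)cc3)cc2)nc2c(Cl)c(Cl)sc12`, 230 nM
compound 2 `CN(C)CCCNc1nc(-c2ccc(NC(=O)Nc3ccc(Cl)cc3Cl)cc2)nc2c(Cl)c(Cl)sc12`, 980 nM

Compound 1 gives the lowest number of the two measured; its nearest neighbour is compound 2, which differs by a 4.3-fold higher number from compound 1 to compound 2 (0.63 log units; beyond the scatter), a change on the aryl urea, not on the basic side chain.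

Compound 3 `CCN(CC)CCNc1nc(-c2ccc(NC(=O)Nc3ccc(Cl)cc3)cc2)nc2c(Cl)c(Cl)sc12` is not yet measured. It differs from compound 1 by diethylamino in place of (dimethylamino)methyl on a saturated chain carbon, two bonds along the chain from a nitrogen on an aromatic ring. Among the measured compounds shown here, no measured step touches this part of the molecule: the single step available, from compound 1 to compound 2, lies on the aryl urea and says nothing about the side-chain amine. The two amines carry the same counted donors and acceptors and no net charge; the number is therefore expected to stay close to that of compound 1, with a step of about a 1.1-fold higher number from compound 1 to compound 3 (0.04 log units; within the scatter), that is none beyond the scatter.

Compound 3 is estimated at 250 nM in this assay, with a range from 100 nM to 650 nM.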

Compound 3, half-maximal inhibitory concentration: 320 nM
Estimate against measurement, compound 3: 1.3-fold (0.11 log units) below, and the stated range covers the measured number.
By their numbers in this assay, from the lowest: compounds 1 and 3 (each within the scatter of the next); then compound 2.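

In this assay, among the compounds shown here, diethylamino in place of (dimethylamino)methyl on a saturated chain carbon, two bonds along the chain from a nitrogen on an aromatic ring, gives a 1.4-fold higher number from compound 1 to compound 3 (0.14 log units; within the scatter) and is the first reading at this part of the molecule. The 3-(dimethylamino)propyl and 2-(diethylamino)ethyl side chains thus read alike, whereas a 4.3-fold higher number from compound 1 to compound 2 (0.63 log units; beyond the scatter) on the aryl urea remains the only step beyond the scatter among the compounds shown. No evidence on the reason for this result is at hand.

The exchange alters the chain and the amine together, so the two contributions cannot be separated from these compounds. Also open, as far as these compounds go, are how a primary amine, a carboxylic acid or a longer chain would read here, and whether the same exchange reads alike on the core of compound 2.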